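From a Methylpyridinyl to a Methoxymethylphenyl Substituent

This account rests on a few compounds, and the source may have more. Where it says the series, first, only, none or still open, it means among the compounds named here.

Compound 1 `CC[C@@H](Nc1c(C#N)c(-c2ccc(-c3cccnc3C)cc2)nc2cnccc12)C(N)=O`: 1.9
Compound 2 `CCOc1ccccc1-c1ccc(-c2nc3cnccc3c(C[C@H](C)C(=O)O)c2C#N)cc1`: 2.2
Compound 3 `CCOc1ccccc1-c1ccc(-c2nc3cnccc3c(N[C@H](CC(C)C)C(N)=O)c2C#N)cc1`: 3.4

In a physicochemical assay for lipophilicity, read by HPLC, at pH 7.5 (a lower number here means a more polar compound, a higher number a more lipophilic compound), compound 1 gives the lowest of the three numbers; compound 2 lies within the scatter of it, while compound 3 stands well beyond. Going by the values given here, the only single-point step among the measured compounds is a number 1.20 log units higher from compound 2 to compound 3 (beyond the scatter), which concerns the side chain rather than the aryl substituent. Compound 4 `CC[C@@H](Nc1c(C#N)c(-c2ccc(-c3ccccc3COC)cc2)nc2cnccc12)C(N)=O` differs from compound 1 in that aryl substituent: 2-(methoxymethyl)phenyl in place of 2-methylpyridin-3-yl on an aromatic carbon. Among the compounds with values here, no measured step tracks this change, so the comparison rests on the change itself. The piece expects a rise in this assay of a number 0.90 log units higher from compound 1 to compound 4 (beyond the scatter) for compound 4, beyond the scatter. Compound 4 is thus estimated at 2.8, between 2.2 and 3.4.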

Compound 4, distribution coefficient: 2.6
For compound 4 the middle estimate is 0.20 log units above the measured one, within the range that was stated.
By their numbers in this assay, from the lowest: compounds 1 and 2 (each within the scatter of the next); then compound 4; then compound 3.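

With the side chain of compound 1 held fixed, the substituent at this position alone moves the reading in this assay: 2-(methoxymethyl)phenyl in place of 2-methylpyridin-3-yl gives a number 0.70 log units higher from compound 1 to compound 4 (beyond the scatter) on the shared core. Going by these compounds alone, the only step available before this one concerned the side chain, so this is the first measured change at this aryl position. Nothing measured here accounts for the size of the step.

From the compounds shown here alone, whether the step carries over to other side chains remains open. So does how an aminomethyl or hydroxymethyl group would read in place of the methoxymethyl group.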